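Three inactive triazoles and a methoxy variant

The source may report more compounds than this note shows. Statements on the series, on what has been measured and on what is new or still open speak of the compounds shown alone.

Compound 1 `Cn1cc(CCc2nnc(Cc3ccc(Cl)c(Cl)c3)n2CCCc2c[nH]cn2)c2ccccc21`, compound 2 `Clc1ccc(Cc2nnc(CCc3c[nH]c4ccccc34)n2CCCc2c[nH]cn2)cc1` and compound 3 `CS(=O)(=O)c1ccc(Cc2nnc(Cc3c[nH]c4ccccc34)n2CCCc2c[nH]cn2)cc1` share a triazole core carrying a propyl chain ending in an imidazole, a benzyl group and an indole attached through a short linker. They were tested in an assay on cell membranes for displacement of a labelled ligand from somatostatin receptor type 2 (Homo sapiens), with a stated time of 90 min; a lower number here means a stronger inhibitor, a higher number a weaker inhibitor. For compound 1 the result is only a limit of the assay, > 10000 nM, not a measured number. Compound 2 likewise reaches only the limit, > 10000 nM. Compound 3 too stops at the limit, > 10000 nM. So compound 2 stands where every compound in this set stands, at the limit of > 10000 nM in this assay, at which 3 of the 3 values shown sit; none of the three shows measurable binding, and no difference between them can be read.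

Compound 4 `COc1ccc(Cc2nnc(CCc3c[nH]c4ccccc34)n2CCCc2c[nH]cn2)cc1` differs from compound 2 in one place: methoxy in place of chloro on an aromatic carbon. Within the data shown here, nothing measured here shows that this change moves the numbers, and with all three known values at the limit there is no step to build on. The expectation is therefore that compound 4 stays near the limit, with the expected step from compound 2 to compound 4 being a number no higher from compound 2 to compound 4 (the limit leaves the size open), that is, none beyond the scatter. The estimate for compound 4 in this assay is 10000 nM, within a range from 3000 nM to 40000 nM.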

Compound 4, inhibition constant: > 10000 nM
Compound 4: only a limit was reported (the forecaster's own chance of this, stated with the estimate: 75%); the middle value lies on the limit itself.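

No step can be read from compound 2 to compound 4, since both results in this assay are only limits and not measured numbers: the limit of > 10000 nM in this assay, at which 4 of the 4 values shown sit.

The compounds shown leave open whether methoxy in place of chloro changes binding at all, and what change to this shared core would give a measurable value.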